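A few compounds are considered here, and "the series" means these few. Any claim that something is new, unique, unknown or untested is made for them only; others in the source may bear on it.

Both measured compounds share the same core, a fused ring system carrying three methoxy groups, with a phenyl ring attached that bears an amide-linked substituent. Compound 1 `COc1cc2oc(-c3cccc(NC(=O)c4ccc(Cl)cc4)c3)cc(=O)c2c(OC)c1OC` carries a (4-chlorophenyl)carbonylamino group on that phenyl ring. In a functional assay on UO-31 cells (Homo sapiens) for inhibition, read by sulforhodamine B assay, tested at 10 uM (on this read-out higher numbers stand for more inhibition at the one concentration tested (going by the name of the read-out) and lower numbers for less inhibition), compound 1 gives 51.1%. Compound 2 `COc1cc2oc(-c3cccc(NC(=O)c4cccc(C#N)c4)c3)cc(=O)c2c(OC)c1OC` is the close relative in which the chlorine is replaced by a nitrile. In this assay compound 2 is reported only as "active" (no number reported), with no number attached, so where compound 2 stands can be said only in words: it inhibited the cells, and the size of that inhibition is not known.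

Compound 3 `COc1cc2oc(-c3cccc(C(=O)Nc4ccc(C)cc4)c3)cc(=O)c2c(OC)c1OC` has not yet been measured. It differs from compound 2 in one place: (4-methylphenyl)carbamoyl in place of ((3-cyanophenyl)carbonyl)amino on an aromatic carbon. Among the compounds with values here, no step between two measured compounds is available to guide the size of this change. With compound 2 reported only as "active" (no number reported) and without a number, the step from compound 2 to compound 3 in this assay is expected to be of modest size, more likely downward than upward, though a result within the usual scatter would not be surprising.

Compound 3 is expected to give about 40% in this assay, in a range from 15% to 65%.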

Compound 3, a percentage reported as inhibition, at one concentration (the size of the read-out at that concentration, not a potency): 55.7%
Estimate against measurement, compound 3: 15.7 percentage points below; measured number inside the range.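

In this assay, putting (4-methylphenyl)carbamoyl in place of ((4-chlorophenyl)carbonyl)amino, on the aromatic carbon meta to a large group, gives a number 4.6 percentage points higher from compound 1 to compound 3 (within the scatter), so this read-out does not separate the two groups. This single swap alters two features at once: the amide is turned around, with its carbonyl rather than its nitrogen now attached to the ring, and a methyl group stands where the chlorine stood, yet the combined change leaves the result within the usual scatter. Compound 2 has no number and its step to compound 3 cannot be read, and nothing measured here accounts for the result.

On these data alone, whether turning the amide around and replacing chlorine with methyl would each leave the result unchanged on their own remains open, since the two changes could also offset each other. Also open, as far as these compounds go, is what an amine or a carboxylic acid in place of the methyl group would give, or a longer chain in place of the amide.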